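A few compounds are considered here, and "the series" means these few. Any claim that something is new, unique, unknown or untested is made for them only; others in the source may bear on it.

Measured so far in an ADME assay on MT4 cells (Homo sapiens) for cytotoxicity, read by MTT assay, with a stated time of 5 days; on this read-out higher numbers stand for lower toxicity in this test and lower numbers for higher toxicity in this test:

Compound 1 `COc1cc2nc(SCC(=O)Nc3ccc([N+](=O)[O-])cc3)nc(Nc3c(C)cc(/C=C/C#N)cc3C)c2cc1OC` gives > 219000 nM
Compound 2 `COc1cc2nc(SCC(=O)Nc3ccc(F)cc3)nc(Nc3c(C)cc(/C=C/C#N)cc3C)c2cc1OC` gives >= 150000 nM

Compound 2 stands only at a limit (>= 150000 nM) and not at a number. Compound 1 also gives a limit (> 219000 nM). Compound 3 `COc1cc2nc(SCC(=O)Nc3ccc(C(F)(F)F)cc3)nc(Nc3c(C)cc(/C=C/C#N)cc3C)c2cc1OC` changes compound 2 in one place (trifluoromethyl in place of fluoro on an aromatic carbon), with trifluoromethyl in place of fluoro on an aromatic carbon, para to a large group. Going by the values given here, the only measured step (a step that the two limits leave unreadable from compound 1 to compound 2) has no readable size, so no step beyond the usual scatter is expected in this assay and no direction can be given. The expected step is a number no higher from compound 2 to compound 3 (the limit leaves the size open) and it is only an estimate. For compound 3 the estimated value is 150000 nM with an expected range from 70000 nM to 280000 nM and a report as a limit is likely.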

Compound 3, half-maximal cytotoxic concentration: > 211000 nM
Compound 3: no number, only a limit (the forecaster's own chance of this, stated with the estimate: 75%); middle value at least 1.4-fold (0.14 log units) from the limit.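

Compound 1, compound 2 and compound 3 each give only a limit, not a number, and the steps between them cannot be read. The compounds shown leave open whether swapping nitro, fluoro and trifluoromethyl changes the outcome in this assay at all.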